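The source may report more compounds than this note shows. Statements on the series, on what has been measured and on what is new or still open speak of the compounds shown alone.

The series shares one core, seen in compound 1 `COc1ccc(-c2nnc(N3CCN(C(=O)CN4CCN(c5ccccc5)CC4)CC3)nc2-c2ccc(OC)cc2)cc1` and compound 2 `COc1ccc(-c2nnc(N3CCN(C(=O)CN4CCN(c5cccc(OC)c5)CC4)CC3)nc2-c2ccc(OC)cc2)cc1`. In an ADME assay on NIH3T3 cells (Mus musculus) for cytotoxicity, read by MTT assay, with a stated time of 24 h (on this read-out lower numbers stand for stronger inhibition and higher numbers for weaker inhibition), compound 1 reaches only a limit of the assay, > 863000 nM. In this assay compound 2 likewise reaches only a limit, > 821000 nM. The step that the two limits leave unreadable from compound 1 to compound 2 is therefore unreadable. Compound 3 `O=C(CN1CCN(c2ccccc2Cl)CC1)N1CCN(c2nnc(-c3ccc(Cl)cc3)c(-c3ccc(Cl)cc3)n2)CC1` belongs to the same series, and in this assay compound 3 again sits at a limit, > 803000 nM. Where compound 3 stands can thus be said only in terms of limits: the limit of > 803000 nM in this assay, at which 1 of the 3 values shown sits, the limit of > 821000 nM in this assay, at which 1 of the 3 values shown sits, and the limit of > 863000 nM in this assay, at which 1 of the 3 values shown sits, together mean that no value in the set is a number.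

Compound 4 `COc1ccc(N2CCN(CC(=O)N3CCN(c4nnc(-c5ccc(Cl)cc5)c(-c5ccc(Cl)cc5)n4)CC3)CC2)cc1` differs from compound 3 by 4-methoxyphenyl in place of 2-chlorophenyl on an amine nitrogen in a ring. For the measured compounds named here, no measured step bears on this change, since the single step between measured compounds is itself unreadable. Going by the values given here, with every value so far a limit, no step beyond the scatter is expected in this assay. The step that the limit leaves unreadable from compound 3 to compound 4 is the expected outcome. Compound 4 is expected to give 900000 nM in this assay, within 400000 nM to 2000000 nM, most probably again as a limit.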

Compound 4, half-maximal inhibitory concentration: > 809000 nM
Compound 4 ended at the assay's limit (the forecaster's own chance of this, stated with the estimate: 85%); the middle value does not contradict the limit.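

In this assay compound 4 gives only a limit, > 809000 nM. Compound 3 also gives only a limit, > 803000 nM, so no step can be read between compound 3 and compound 4. The compounds shown leave open at what concentration any member of this series reaches half-maximal inhibition.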